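Replacing 4-methoxyphenyl with 4-bromophenyl

A few compounds are considered here, and "the series" means these few. Any claim that something is new, unique, unknown or untested is made for them only; others in the source may bear on it.

In a functional assay on MCF7 cells (Homo sapiens) for antiproliferative activity, read by MTT assay, with a stated time of 72 h (a higher number here means a weaker inhibitor, a lower number a stronger inhibitor), compound 1 (`Cc1ccc(-c2c(CN3CCCCC3)nc3scc(C(=O)O)n23)cc1`) gives 8290 nM, while compound 2 (`COc1ccc(-c2c(CN3CCCCC3)nc3scc(C(=O)O)n23)cc1`) gives 62900 nM, the higher of the two numbers and so the weaker result. Compound 3 (`O=C(O)c1csc2nc(CN3CCCCC3)c(-c3ccc(Br)cc3)n12`) keeps the shared core but carries bromo in place of methoxy on an aromatic carbon, para to a large group: bromo in place of methoxy on an aromatic carbon. Within the data shown here, one measured step bears on this change: a 7.6-fold higher number from compound 1 to compound 2 (0.88 log units; beyond the scatter), a modest step beyond the scatter, with methoxy in place of methyl. Going by that step, losing the methoxy is expected to recover part of the difference, although no measured compound shows what bromo itself does. A lower number of moderate size is therefore expected, an estimated 3.5-fold lower number from compound 2 to compound 3 (0.54 log units; beyond the scatter). For compound 3 the expected value is 18000 nM, with an estimated range of 5000 nM to 55000 nM.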

Compound 3, half-maximal inhibitory concentration: 87500 nM
Compound 3: the middle estimate sits 4.9-fold (0.69 log units) below what was measured; measured number outside the range, above it.
By their numbers in this assay, from the lowest: compound 1; then compounds 2 and 3 (each within the scatter of the next).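

Bromo in place of methoxy does not bring the number back toward that of compound 1: in this assay the change gives a 1.4-fold higher number from compound 2 to compound 3 (0.14 log units; within the scatter), so at this position the two groups cannot be told apart. Set against the methyl group, bromo gives an 11-fold higher number from compound 1 to compound 3 (1.02 log units; beyond the scatter), which leaves compound 1 as the strongest of the three, with both other groups on the 4-substituted phenyl ring beyond the scatter from it. Nothing available here explains why methyl stands apart from methoxy and bromo at this position.

The compounds shown leave open whether any other group at this position, such as chloro, ethyl or an amine, would match or pass methyl. They also leave open whether a plain phenyl ring, with only a hydrogen there, would do the same.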